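The compounds below may be only part of what the source reports. "The series", "measured", "known", "first", "only" and "open" are said of these compounds alone.

Measured so far:
compound 1, `O=C1NC(=O)/C(=C/c2ccc(OCc3csc(-c4ccccc4)n3)cc2)S1`: 22.6%
compound 2, `Cc1ccc(-c2nnc(SCCOc3ccc(/C=C4\SC(=O)NC4=O)cc3)[nH]2)cc1`: 22.6%

Both compounds were tested in a functional assay on the whole organism (plasma, strain Wistar) with Rattus norvegicus as the target, with a stated time of 15 days, at a dose of 30 mg/kg by the oral route; on this read-out higher numbers stand for a stronger effect at the one dose given and lower numbers for a weaker effect. In this test compound 1 gives 22.6%, and compound 2 gives 22.6%. The two figures are identical, so compound 2 stands level with compound 1, with no difference between them beyond the usual scatter of such a measurement. For the measured compounds named here, nothing here shows how one small change in structure moves the read-out, since no two measured compounds differ in only one place.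

Compound 3, `O=C1NC(=O)/C(=C/c2ccc(OCCSc3nnc(-c4ccc(Br)cc4)[nH]3)cc2)S1`, has not yet been measured in this assay. It differs from compound 2 in a single spot: bromo in place of methyl on an aromatic carbon. Neither the ring count nor the donors, acceptors or charge move with this swap. Going by the values given here, with no measured step of this kind to lean on, the most reasonable expectation is a step from compound 2 to compound 3 of a number 0.4 percentage points higher from compound 2 to compound 3 (within the scatter), which is to say none beyond the scatter. Compound 3 is therefore estimated at 23%, with a range expected from 10% to 40%.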

Compound 3, a percentage reported as activity, at one dose (the size of the read-out at that dose, not a potency): 19.5%
The estimate for compound 3 lay 3.5 percentage points above the measured number; measured number inside the range.
By their numbers in this assay, from the lowest: compounds 3, 1 and 2 (each within the scatter of the next).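

In this assay, for the compounds shown here, bromo in place of methyl on an aromatic carbon, para to a large group, gives a number 3.1 percentage points lower from compound 2 to compound 3 (within the scatter), the first comparison here between two compounds that differ in only one place. At this one dose, then, going from 4-methylphenyl to 4-bromophenyl leaves the read-out within the usual scatter, even though a carbon atom gives way to a much heavier bromine atom. The count of heavy atoms, hydrogen-bond donors and hydrogen-bond acceptors stays the same in this change, and no measurement at hand offers an explanation for the result.

Methyl and bromo are both groups of a single heavy atom, so the compounds shown leave open whether anything larger or of another kind, such as an amine, a carboxylic acid or a longer alkyl chain, would move the read-out beyond the scatter at this position. They also leave open whether bromo on a different carbon of the same ring would read the same, and how either group would behave at another dose.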